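Series notes: trifluoromethyl in place of methyl on compound 3

A few compounds are considered here, and "the series" means these few. Any claim that something is new, unique, unknown or untested is made for them only; others in the source may bear on it.

In an ADME assay on HepG2 cells (Homo sapiens) for cytotoxicity, read by MTT assay, with a stated time of 48 h (a higher number here means that more compound is tolerated, a lower number that less compound is tolerated), compound 3 `C#CCN(c1nc(-c2ccc(C)cc2)no1)C1CCCCC1` gives 91.9 ug/mL. Compound 1 `CC(=O)OC[C@H]1O[C@H](OC[C@H](Cn2cc(-c3ccc(-c4noc(NC5CCCCC5)n4)cc3)nn2)OC(C)=O)C=C[C@@H]1OC(C)=O` gives 79.8 ug/mL, which lies within the scatter of compound 3. Compound 2 `CC(=O)OC[C@H]1O[C@H](OC[C@@H](Cn2cc(CN(c3nc(-c4ccc(C)cc4)no3)C3CCCCC3)nn2)OC(C)=O)C=C[C@@H]1OC(C)=O` gives 36.8 ug/mL, lower than compound 3 by more than the scatter. Compound 3 therefore sits in the upper pair of the three values, level with compound 1 and clear of compound 2.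

The next entry is compound 4 `C#CCN(c1nc(-c2ccc(C(F)(F)F)cc2)no1)C1CCCCC1`, not yet measured in this assay. It carries trifluoromethyl in place of methyl on an aromatic carbon, para to a large group (trifluoromethyl in place of methyl on an aromatic carbon). Everything else matches compound 3.

Among the measured compounds shown here, no two measured compounds differ in one place only, so the series offers no measured size for this or any other single change. Compounds 1 and 2 each differ from compound 3 in several places and say little about this step. The expectation therefore rests on compound 3 at 91.9 ug/mL as the closest structure, with no direction favoured beyond the scatter.

The expected 1.1-fold lower number from compound 3 to compound 4 (0.06 log units; within the scatter) stays within the scatter. For compound 4 the estimated value is 80 ug/mL, with an expected range of 42 ug/mL to 150 ug/mL.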

Compound 4, half-maximal cytotoxic concentration: 61.9 ug/mL
Compound 4: middle estimate off by 1.3-fold (0.11 log units), on the high side; the measured number falls inside the stated range.
By their numbers in this assay, from the lowest: compounds 2, 4, 1 and 3 (each within the scatter of the next, the first and the last beyond it).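

In this assay the series now holds its first step that differs in one place only (a 1.5-fold lower number from compound 3 to compound 4 (0.17 log units; within the scatter)), and this step lies within the scatter. On an aromatic carbon para to a large group, trifluoromethyl in place of methyl therefore gives no readable difference in tolerated concentration, even though the group grows from 1 heavy atom to 4 heavy atoms, so this position accepts this one exchange without a measurable shift on the frame of compound 3. No measurement on hand bears on why the exchange leaves the number within the scatter.

The compounds shown leave open whether a different group on this aromatic carbon, such as a methoxy group, an amine or a carboxylic acid, would move the number beyond the scatter. They also leave open whether trifluoromethyl in place of methyl would give a step of similar size on the larger frame of compound 2, since this single step comes from one pair on one frame and sets no general rule for the series.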